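Swapping the aryl group on the amine of compound 1

A few compounds are considered here, and "the series" means these few. Any claim that something is new, unique, unknown or untested is made for them only; others in the source may bear on it.

Measured compounds:
compound 1 `Cc1ccc(NC2=CC(=O)c3nc4n(c3C2=O)[C@H]2OC[C@@H](O)[C@H]2OC4)cc1C`: 2690 nM
compound 2 `O=C1C(Nc2cccc(Cl)c2)=CC(=O)c2c1nc1n2[C@H]2OC[C@@H](O)[C@H]2OC1`: 7970 nM
compound 3 `CCCc1ccc(NC2=CC(=O)c3c(nc4n3[C@H]3OC[C@@H](O)[C@H]3OC4)C2=O)cc1`: 6030 nM

In a functional assay on HeLa cells (Homo sapiens) for inhibition, read by sulforhodamine B assay (on this read-out higher numbers stand for weaker inhibition and lower numbers for stronger inhibition), compound 1 gives 2690 nM, the lowest of the three numbers. Compound 3 is the nearest to it, with a number higher by a margin beyond the scatter, and compound 2 is furthest, also beyond the scatter. The new compound is compound 4 `CCc1ccc(NC2=CC(=O)c3nc4n(c3C2=O)[C@H]2OC[C@@H](O)[C@H]2OC4)cc1`. It differs from compound 1 in one place: 4-ethylphenyl in place of 3,4-dimethylphenyl on an amine nitrogen. Going by the values given here, the only measured step of the same kind, an exchange of one aryl group for another on that nitrogen, is a 1.3-fold lower number from compound 2 to compound 3 (0.12 log units; within the scatter), which lay within the scatter. That step tells how two other aryl groups compare, not how 4-ethylphenyl compares with 3,4-dimethylphenyl, so it gives only a rough guide; the groups of compound 3 and compound 4 share a chain on the ring, which suggests compound 4 may sit between compound 1 and compound 3. A small step upward in this assay, a 1.5-fold higher number from compound 1 to compound 4 (0.17 log units; within the scatter), is therefore expected, near or at the edge of the scatter. Compound 4 is estimated at 4000 nM, within 1800 nM to 9000 nM.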

Compound 4, half-maximal inhibitory concentration: 3990 nM
Estimate against measurement, compound 4: 1.0-fold (0.00 log units) above, within the range that was stated.
By their numbers in this assay, from the lowest: compounds 1, 4, 3 and 2 (each within the scatter of the next, the first and the last beyond it).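

In this assay, putting 4-ethylphenyl in place of 3,4-dimethylphenyl on the amine nitrogen gives a 1.5-fold higher number from compound 1 to compound 4 (0.17 log units; within the scatter), so this exchange cannot be told apart from the scatter. The two groups hold the same atoms, joined differently, and this is what the earlier step between compounds with different atoms on that nitrogen could not show: here, rearranging those carbons on the aryl ring leaves the number within the scatter. Nothing at hand gives a reason for this result.

On these data alone, it remains open how a longer chain such as butyl, or a methoxy group, a carboxylic acid or an amine on the aryl ring, would read in this assay. The compounds shown also leave open whether a cyclohexyl group could stand in place of the aryl ring on that nitrogen.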